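A Methyl Added to the Core in Two Compound Pairs

The source may hold more compounds than are shown below. What is called first, only, known or untested is meant among the compounds shown, and "the series" means these compounds.

Compound 1 `COc1ccc(-c2cc(-c3ccc(OC)cc3)on2)cc1` and compound 2 `COc1ccc(-c2noc(-c3ccc(OC)cc3)c2C)cc1` differ by methyl in place of hydrogen on an aromatic carbon. In an ADME assay (Mus musculus) for antiproliferative activity, read by cell counting, with a stated time of 5 days (a higher number here means a weaker inhibitor, a lower number a stronger inhibitor), compound 1 gives only a limit of the assay, > 100000 nM. Compound 2 likewise gives only a limit, > 100000 nM. The step that the two limits leave unreadable from compound 1 to compound 2 therefore cannot be read, because of the limit of > 100000 nM in this assay, at which 2 of the 3 values shown sit. Compound 3 `Oc1ccc(-c2cc(-c3ccc(O)cc3)on2)cc1` rests on a different core; how its core differs from that of compound 1 is not broken down here. In this assay compound 3 gives 2500 nM. Compound 4 `Cc1c(-c2ccc(O)cc2)noc1-c1ccc(O)cc1` stands to compound 3 as compound 2 stands to compound 1: the change methyl in place of hydrogen on an aromatic carbon is the same kind of change, the place here being next to two ring atoms that each bear a group of 7 heavy atoms rather than 8. With the earlier step unreadable, the expectation rests only on compound 3 and its value 2500 nM, and the step from compound 3 to compound 4 is estimated at a 1.6-fold higher number from compound 3 to compound 4 (0.20 log units; within the scatter). Compound 4 is expected to give 4000 nM, between 1000 nM and 20000 nM.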

Compound 4, half-maximal inhibitory concentration: 19000 nM
Compound 4: middle estimate off by 4.8-fold (0.68 log units), on the low side; the measured number falls inside the stated range.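

In this assay, methyl in place of hydrogen on an aromatic carbon gives a 7.6-fold higher number from compound 3 to compound 4 (0.88 log units; beyond the scatter), so on this core the change weakens the inhibitor by more than the usual scatter. On the core of compound 1 the same change cannot be read, as the values there stop at a limit of the assay: the limit of > 100000 nM in this assay, at which 2 of the 4 values shown sit. The series therefore offers one readable step and shows nothing about whether its size or direction carries from one core to the other.

On these data alone, it remains open whether ethyl, an amine or a carboxylic acid on that aromatic carbon would give a number closer to that of compound 3. As far as these compounds go, the effect of any such group on the core of compound 1 also remains open.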